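Urea-linked pyrazole series: demethylation of the aryl ether

The source may report more compounds than this note shows. Statements on the series, on what has been measured and on what is new or still open speak of the compounds shown alone.

Measured so far:
compound 1 `O=C(Nc1cccc(-n2cc(-c3ccncc3)c(-c3ccc(Cl)c(O)c3)n2)c1)Nc1cccc(C(F)(F)F)c1` — 980 nM
compound 2 `COc1cc(-c2nn(-c3cccc(NC(=O)Nc4ccc(Cl)c(Cl)c4)c3)cc2-c2ccncc2)ccc1Cl` — 567 nM

Of the compounds shown here, two of the shared core have been measured in a functional assay on MDA-MB-468 cells (Homo sapiens) for inhibition, read by sulforhodamine B assay, with a stated time of 48 h; on this read-out higher numbers stand for weaker inhibition of growth and lower numbers for stronger inhibition of growth. Compound 1 gives 980 nM and compound 2 gives 567 nM; the gap between them sits inside the usual scatter, so on these numbers compound 2 and compound 1 cannot be told apart. Among the compounds with values here, the two compounds differ in two places at once, the aryl ether group and the urea partner, so no single-change step is available from them.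

Compound 3 `O=C(Nc1cccc(-n2cc(-c3ccncc3)c(-c3ccc(Cl)c(O)c3)n2)c1)Nc1ccc(Cl)c(Cl)c1` is the next compound. It keeps the dichlorophenyl urea of compound 2 and changes only the ether: hydrogen in place of methyl on an oxygen on an aromatic ring, that is, methoxy to hydroxy, 4-chloro-3-methoxyphenyl to 4-chloro-3-hydroxyphenyl. Compound 1 carries the same hydroxy group with a different urea partner and gives a number within scatter of compound 2, so nothing measured points to a sizeable move in either direction. The expected step of a 1.2-fold higher number from compound 2 to compound 3 (0.09 log units; within the scatter) is therefore small, within the scatter. Compound 3 is estimated at 700 nM, with a range from 280 nM to 1800 nM.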

Compound 3, concentration for 50% growth inhibition: 729 nM
Compound 3: the middle estimate sits 1.0-fold (0.02 log units) below what was measured, within the range that was stated.
By their numbers in this assay, from the lowest: compounds 2, 3 and 1 (each within the scatter of the next).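

In this assay, within the data shown here, the step of a 1.3-fold higher number from compound 2 to compound 3 (0.11 log units; within the scatter) gives the first single-change reading at this oxygen on an aromatic ring, and it lies within the scatter, so methoxy and hydroxy cannot be told apart on this read-out when the urea partner is 3,4-dichlorophenyl. With the hydroxy group held fixed, the step of a 1.3-fold lower number from compound 1 to compound 3 (0.13 log units; within the scatter) is also within the scatter, so 3,4-dichlorophenyl and 3-(trifluoromethyl)phenyl on the amide-type nitrogen cannot be told apart either, a separation of the two changes that compound 1 and compound 2 could not give, as they differ in two places. No measurement bears on the reason for either result.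

The compounds shown leave open whether an ethoxy group or a longer chain on this oxygen, or an amine in place of the hydroxy group, would give a step beyond the scatter. They also leave open whether methoxy and hydroxy remain indistinguishable with the 3-(trifluoromethyl)phenyl urea partner, and whether either step holds in other cell lines.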